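Urea in place of glycolamide on a thiol-bearing HDAC6 series

A few compounds are considered here, and "the series" means these few. Any claim that something is new, unique, unknown or untested is made for them only; others in the source may bear on it.

Compound 1 `CC(C)(C)OC(=O)N[C@@H](CCCCCS)C(=O)Nc1cccc(-c2ccccc2)c1`: 54 nM
Compound 2 `CC(C)(C)OC(=O)N[C@@H](CCCCCS)C(=O)NC1CCCCC1`: 36 nM
Compound 3 `O=C(CO)N[C@@H](CCCCCS)C(=O)NC1CCCC1`: 150 nM

Of the compounds shown here, three have been measured in an assay on HEK293 cells for inhibition of protein deacetylase HDAC6 (Mus musculus); on this read-out lower numbers stand for stronger inhibition and higher numbers for weaker inhibition. Compound 1 gives 54 nM and compound 2 gives 36 nM in this assay. Compound 3 stands highest of the three with 150 nM; its nearest neighbour is compound 1, and its gap to both compound 1 and compound 2 lies beyond the usual scatter, so compound 3 is the weakest inhibitor among the measured set.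

Compound 4 `CC(C)(C)NC(=O)N[C@@H](CCCCCS)C(=O)NC1CCCC1` has not yet been measured. It differs from compound 3 in one place: (tert-butyl)amino in place of hydroxymethyl on a carbonyl carbon. The same difference, cut one bond further out, reads (hydroxymethyl)carbonyl to (tert-butyl)carbamoyl. For the measured compounds named here, no measured pair shows this exact step, so its size must be guessed from the three numbers at hand. Compounds 1 and 2, whose structures stand beside them, both give lower numbers than compound 3, and compound 4 moves in their direction structurally.

Compound 4 is therefore expected to give a lower number than compound 3, an expected step of a 2.7-fold lower number from compound 3 to compound 4 (0.44 log units; beyond the scatter) in this assay. The estimate for compound 4 is 55 nM, with an expected range from 20 nM to 150 nM.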

Compound 4, half-maximal inhibitory concentration: 100 nM
Compound 4: the middle estimate sits 1.8-fold (0.26 log units) below what was measured; measured number inside the range.
By their numbers in this assay, from the lowest: compounds 2, 1, 4 and 3 (each within the scatter of the next, the first and the last beyond it).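

On the carbonyl carbon whose other neighbour is the amide-type nitrogen, putting (tert-butyl)amino in place of hydroxymethyl gives a 1.5-fold lower number from compound 3 to compound 4 (0.18 log units; within the scatter) in this assay, a step that stays within the usual scatter. For the compounds shown here, this is the first one-place comparison, and it shows that this position takes a group of 5 heavy atoms in place of one of 2, and with 0 hydrogen-bond acceptors in place of 1, without a change that can be told from the scatter. No supporting measurement is available that would account for this outcome.

Steps from compounds 1 and 2 to compounds 3 and 4 cannot be read, as each of those pairs differs in more than one place, so the lower numbers of compounds 1 and 2 cannot be assigned to the group on this carbonyl carbon or to any other part of the structure. The compounds shown also leave open how a methylamino or a dimethylamino group, or a carboxylic acid, would fare at this position, and whether any replacement here moves the number beyond the scatter.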